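The source may report more compounds than this note shows. Statements on the series, on what has been measured and on what is new or still open speak of the compounds shown alone.

Compound 1 `CC1CCN(C2CCN(S(=O)(=O)c3cn(C)cn3)CC2)CC1`: > 10000 nM
Compound 2 `Cc1cc(C)c(S(=O)(=O)c2ccc(N3CCC(C)CC3)cc2)c(C)c1`: > 5000 nM
Compound 3 `CC1CCN(C2CCN(S(=O)(=O)c3ccc(Br)cc3OC(F)(F)F)CC2)CC1`: > 5000 nM

In an ADME assay on HCT-116 cells (Homo sapiens) for cytotoxicity, read by CellTiter-Glo, with a stated time of 72 h (on this read-out lower numbers stand for stronger inhibition and higher numbers for weaker inhibition), compound 1 gives > 10000 nM, which is a limit of the assay and not a number. Compound 2 likewise gives only a limit, > 5000 nM. Compound 3 also gives only a limit, > 5000 nM. Compound 1 therefore stands at the limit of > 10000 nM in this assay, at which 1 of the 3 values shown sits, while the other two stand at the limit of > 5000 nM in this assay, at which 2 of the 3 values shown sit. Among the compounds with values here, none of the three compounds has a measured number, so no step between any pair of them can be sized, and no trend can be drawn from them; the three are known only to be weak in this assay.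

Compound 4 `CC1CCN(C2CCN(S(=O)(=O)c3ccc(Cl)cc3Cl)CC2)CC1` has not yet been measured in this assay. It differs from compound 1 in a single place: 2,4-dichlorophenyl in place of 1-methyl-1H-imidazol-4-yl on a sulfonyl sulfur. Within the data shown here, nothing among the measured compounds shows a sulfonyl substituent of this kind bringing the read-out down to a measurable number, and compound 3 also returns only a limit. The step expected is therefore a number no higher from compound 1 to compound 4 (the limit leaves the size open), none beyond the scatter. Compound 4 is expected to give 10000 nM, with a range of 3000 nM to 30000 nM, and most likely to be reported as a limit once more.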

Compound 4, half-maximal inhibitory concentration: > 5000 nM
Compound 4 ended at the assay's limit; the forecaster's own chance of this, stated with the estimate: 75%; the middle value does not contradict the limit.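

Compound 1 and compound 4 each return only a limit of the assay in this assay, so the step from one to the other cannot be read. The compounds shown leave open whether swapping the group on the sulfonyl sulfur changes the read-out at all, and whether any such group reaches a measurable number.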